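The source may report more compounds than this note shows. Statements on the series, on what has been measured and on what is new or still open speak of the compounds shown alone.

Of the compounds shown here, three have been measured in an ADME assay on BHK cells (Mesocricetus auratus) for cytotoxicity, read by MTT assay, with a stated time of 96 h; a higher number here means that more compound is tolerated, a lower number that less compound is tolerated.

Compound 1 `COc1ccc(-c2nc3cc([N+](=O)[O-])ccc3[nH]2)c(OC)c1OC` gives > 100000 nM, which is a limit of the assay rather than a number.
Compound 2 `COc1cc(OC)cc(-c2nc3cc(C(F)(F)F)ccc3[nH]2)c1` gives > 100000 nM, also a limit.
Compound 3 `COc1ccc(-c2nc3cc([N+](=O)[O-])ccc3[nH]2)c(OC)c1` gives > 100000 nM, also a limit.

The change from compound 1 to compound 3 is hydrogen in place of methoxy on an aromatic carbon. Its step, a step that the two limits leave unreadable from compound 1 to compound 3, cannot be read because of the limit of > 100000 nM in this assay, at which 3 of the 3 values shown sit. Compound 4 `COc1cccc(-c2nc3cc(C(F)(F)F)ccc3[nH]2)c1` has not yet been measured. It differs from compound 2 by hydrogen in place of methoxy on an aromatic carbon, the same kind of change, though here the place is meta to a methoxy group rather than ortho to two methoxy groups. The difference between the cores of compound 1 and compound 2 is not broken down here. For the measured compounds named here, since every value so far sits at the limit, compound 4 is expected to stay there as well, giving an expected step that the limit leaves unreadable from compound 2 to compound 4 in this assay. Compound 4 is therefore estimated at 150000 nM.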

Compound 4, half-maximal cytotoxic concentration: 90000 nM
Compound 4: the middle estimate sits 1.7-fold (0.22 log units) above what was measured; the measured number falls inside the stated range.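

In this assay hydrogen in place of methoxy on the aromatic ring of compound 2 gives an at least 1.1-fold lower number from compound 2 to compound 4 (0.04 log units; that floor lies within the scatter) and only this floor can be read, so the real step may be larger. This does not establish a real drop on this core, and it does not show that the change carries over from one core to another. The same change from compound 1 to compound 3 gives a step that cannot be read, and the two cores cannot be compared, because of what the values share: the limit of > 100000 nM in this assay, at which 3 of the 4 values shown sit.

As far as these compounds go, how far the number moves with other changes on these cores stays open. So does what an amine or a carboxylic acid would give in place of the methoxy group.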